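Extending an Ester Chain and Expected Cytotoxicity

This account rests on a few compounds, and the source may have more. Where it says the series, first, only, none or still open, it means among the compounds named here.

Compound 1, `Cc1cc(C)c(Oc2cc(Nc3ccc(C#N)cc3)ncc2C(=O)NCc2cn(Cc3ccccc3[N+](=O)[O-])nn2)c(C)c1`: > 212000 nM
Compound 2, `Cc1cc(C)c(Oc2cc(Nc3ccc(C#N)cc3)ncc2C(=O)NCc2cn(Cc3ccccc3C#N)nn2)c(C)c1`: > 219000 nM
Compound 3, `COC(=O)Cn1cc(CNC(=O)c2cnc(Nc3ccc(C#N)cc3)cc2Oc2c(C)cc(C)cc2C)nn1`: 13800 nM

In an ADME assay on MT4 cells (Homo sapiens) for cytotoxicity, read by MTT assay, with a stated time of 5 days (on this read-out lower numbers stand for higher toxicity in this test and higher numbers for lower toxicity in this test), compound 3 is the only one of the three with a number; compound 3 gives 13800 nM. Compound 1 reaches only a limit of the test, > 212000 nM. Compound 2 likewise reaches only a limit, > 219000 nM. Compound 4, `CCOC(=O)CCn1cc(CNC(=O)c2cnc(Nc3ccc(C#N)cc3)cc2Oc2c(C)cc(C)cc2C)nn1`, differs from compound 3 by (ethoxycarbonyl)methyl in place of methoxycarbonyl on a saturated chain carbon bound to an aromatic nitrogen. The measured steps that touch this part of the molecule are an at least 15-fold lower number from compound 1 to compound 3 (1.18 log units; beyond the scatter) and an at least 15-fold lower number from compound 2 to compound 3 (1.20 log units; beyond the scatter). Both swap an aromatic group for the ester, a far larger change than lengthening the ester chain. Among the compounds with values here, no measured step tests the chain length alone. The step of a 1.1-fold higher number from compound 3 to compound 4 (0.04 log units; within the scatter) is therefore expected to stay within the scatter. Compound 4 is estimated at 15000 nM, between 5000 nM and 60000 nM.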

Compound 4, half-maximal cytotoxic concentration: 21500 nM
Estimate against measurement, compound 4: 1.4-fold (0.16 log units) below; the measured number falls inside the stated range.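

Lengthening methoxycarbonyl to (ethoxycarbonyl)methyl tests chain length at this position directly, and the change stays within the usual scatter (a 1.6-fold higher number from compound 3 to compound 4 (0.19 log units; within the scatter)). The gap between the esters and the aromatic groups persists with the longer ester (an at least 10-fold lower number from compound 2 to compound 4 (1.00 log units; beyond the scatter)) and (an at least 9.8-fold lower number from compound 1 to compound 4 (0.99 log units; beyond the scatter)). Those two steps start from limits of the test for compound 1 and compound 2, not from numbers, so each gives only a minimum size. The compounds shown leave open how a carboxylic acid in place of the ester, or a still longer chain, would read here.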